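Carbamate series at the muscarinic M5 receptor: next step

The compounds below may be only part of what the source reports. "The series", "measured", "known", "first", "only" and "open" are said of these compounds alone.

Measured so far:
- compound 1 `COc1ccc(CCOC(=O)N(c2ccccc2)C2CN3CCC2CC3)cc1` gives 230 nM in an assay on CHO cells for displacement of a labelled ligand from muscarinic acetylcholine receptor M5 (Homo sapiens), read by scintillation counting, with a stated time of 2 h; on this read-out lower numbers stand for stronger inhibition and higher numbers for weaker inhibition
- compound 2 `O=C(OCCCc1ccc(F)c(F)c1)N(c1ccccc1)C1CN2CCC1CC2` gives 100 nM in this assay

Going by the values given here, compound 2 stands lowest of the two numbers; the only measured step, a 2.3-fold lower number from compound 1 to compound 2 (0.36 log units; beyond the scatter), separates it from compound 1 and lies beyond the scatter, so compound 2 is the stronger binder of the pair.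

Compound 3 `COc1ccc(CCOC(=O)N(c2ccccc2)C2CN3CCC2CC3)cc1OC` differs from compound 2 by 3,4-dimethoxyphenyl in place of 3,4-difluorobenzyl on a saturated chain carbon, two bonds along the chain from an oxygen next to a carbonyl group. Among the compounds with values here, the one measured step that bears on this change is a 2.3-fold lower number from compound 1 to compound 2 (0.36 log units; beyond the scatter), since compound 3 resembles compound 1 more closely than compound 2 does: the difluorobenzyl group leaves and a methoxy-bearing aromatic ring returns. The step from compound 2 to compound 3 is therefore expected to run in the opposite direction, giving a modestly higher number, roughly back to the level of compound 1. Within the data shown here, no measured pair speaks to the 3,4-dimethoxyphenyl group itself, so the range is kept wide. For compound 3 in this assay the expected value is 250 nM with a range from 100 nM to 650 nM. That estimate corresponds to a step of a 2.5-fold higher number from compound 2 to compound 3 (0.40 log units; beyond the scatter).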

Compound 3, inhibition constant: 3490 nM
Compound 3: the middle estimate sits 14-fold (1.14 log units) below what was measured; the whole stated range lies below it.
By their numbers in this assay, from the lowest: compound 2; then compound 1; then compound 3.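

In this assay this position proves far more sensitive than the first step suggested: adding one methoxy in place of hydrogen on an aromatic carbon gives a 15-fold higher number from compound 1 to compound 3 (1.18 log units; beyond the scatter), a large step against the modest 2.3-fold lower number from compound 1 to compound 2 (0.36 log units; beyond the scatter). Going by these compounds alone, the change from 3,4-difluorobenzyl to 3,4-dimethoxyphenyl gives a 35-fold higher number from compound 2 to compound 3 (1.54 log units; beyond the scatter), so a methoxy-bearing ring at this place does not by itself keep a number near that of compound 1, and the extra methoxy is the one difference that separates compound 3 from compound 1. Nothing available explains the size of these steps.

The step from compound 2 changes the ring substituents and the link between ring and chain together, so their separate shares cannot be read; 3,4-difluorophenyl and 3,4-dimethoxybenzyl groups at this place would pull the two apart. On these data alone, it also remains open whether the loss is specific to methoxy or extends to other groups on the same ring, such as hydroxy, chlorine or an amine.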